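The source may report more compounds than this note shows. Statements on the series, on what has been measured and on what is new or still open speak of the compounds shown alone.

Compound 1 `COc1cc(C)c(/C=C/C(C)=C(F)/C=C/C(C)=C/C(=O)O)c(C)c1C` stands highest of the two compounds measured in a functional assay on the whole organism (strain Hart Swiss) with Mus musculus as the target, with stated times of 5 days and 2 weeks, at a dose of 20 mg/kg by the intraperitoneal route; a higher number here means a stronger effect of the compound at the dose given, a lower number a weaker effect: in this assay compound 1 gives 87%, while compound 2 `CCOC(=O)/C=C(C)/C(F)=C/C=C(C)/C=C/c1c(C)cc(OC)c(C)c1C` gives 62%, a gap beyond the usual scatter. Compound 3 `COC(=O)/C=C(C)/C=C/C(F)=C(C)/C=C/c1c(C)cc(OC)c(C)c1C` has not yet been measured. It differs from compound 1 by methyl in place of hydrogen on an oxygen next to a carbonyl group. Among the measured compounds shown here, no measured pair shows this change on its own, so its effect is not known. A moderate decrease is nonetheless expected in this assay, a number 22 percentage points lower from compound 1 to compound 3 (beyond the scatter). This expectation rests on compound 2, which gives 62%. Compound 3 is expected to give 65%, with a range from 45% to 85%.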

Compound 3, a percentage reported as activity, at one dose (the size of the read-out at that dose, not a potency): 60%
Compound 3: middle estimate off by 5 percentage points, on the high side, within the range that was stated.
By their numbers in this assay, from the lowest: compounds 3 and 2 (each within the scatter of the next); then compound 1.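

In this assay the change from carboxy to methoxycarbonyl, with methyl in place of hydrogen on an oxygen next to a carbonyl group, gives a number 27 percentage points lower from compound 1 to compound 3 (beyond the scatter) and so shows directly, in a pair differing only in this place, that this change lowers the effect at the dose given. Nothing available explains this fall.

On these data alone, whether an amide in place of the carboxy group, or a propyl chain on this oxygen, would lower the effect to the same extent stays open. This single pair also cannot show whether the step would hold on another core.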